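Cytotoxicity of Adenosine-like Nucleosides: Indole Replaced by Methylsulfanyl

A few compounds are considered here, and "the series" means these few. Any claim that something is new, unique, unknown or untested is made for them only; others in the source may bear on it.

Compound 1 `OC[C@H]1O[C@@H](n2cnc3c(COc4ccccc4)ncnc32)[C@H](O)[C@@H]1O` gives > 100000 nM in a functional assay on Huh-7 cells (Homo sapiens) for cytotoxicity, read by MTT assay, with a stated time of 3 days (a lower number here means that less compound is tolerated, a higher number that more compound is tolerated), which is a limit of the assay rather than a number.
Compound 2 `O=C(O)CNCc1ncnc2c1ncn2[C@@H]1O[C@H](CO)[C@@H](O)[C@H]1O` gives > 100000 nM in this assay, again only a limit.
Compound 3 `OC[C@H]1O[C@@H](n2cnc3c(Cn4ccc5ccccc54)ncnc32)[C@H](O)[C@@H]1O` gives > 250000 nM in this assay, also a limit.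

Going by the values given here, no measured compound has a true number here: all three sit at a limit, meaning no half-maximal cytotoxic concentration was reached. Compound 3 stands at the limit of > 250000 nM in this assay, at which 1 of the 3 values shown sits, whereas the other two stand at the limit of > 100000 nM in this assay, at which 2 of the 3 values shown sit. The steps a step that the two limits leave unreadable from compound 1 to compound 3 and a step that the two limits leave unreadable from compound 2 to compound 3 therefore cannot be read in size or direction, and the same holds for a step that the two limits leave unreadable from compound 1 to compound 2.

Compound 4 `CSCc1ncnc2c1ncn2[C@@H]1O[C@H](CO)[C@@H](O)[C@H]1O` differs from compound 3 by methylsulfanyl in place of 1H-indol-1-yl on a saturated chain carbon bound to an aromatic carbon. Since every measured step is unreadable, no step beyond the scatter can be predicted for this change in this assay; the expectation is simply that compound 4, like compound 3, is tolerated up to the tested range. Compound 4 is estimated at 200000 nM, between 80000 nM and 500000 nM, an expected step of an at least 1.2-fold lower number from compound 3 to compound 4 (0.09 log units; that floor lies within the scatter), most likely reported again as a limit.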

Compound 4, half-maximal cytotoxic concentration: > 100000 nM
Compound 4: no number, only a limit (the forecaster's own chance of this, stated with the estimate: 85%); the middle value is on the limit's open side.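

Compound 4 also sits at a limit rather than a number, and its steps from compound 1, compound 2 and compound 3 cannot be read in size or direction. The compounds shown leave open what concentration would reach the half-maximal cytotoxic level in this assay.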